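The source may hold more compounds than are shown below. What is called first, only, known or untested is meant among the compounds shown, and "the series" means these compounds.

Measured so far: compound 3 `CN(C)C1(Cc2ccccc2)CCN(c2cc(C(F)(F)F)ccc2CNC(=O)Nc2cccc3c(=O)[nH]ccc23)CC1` with 111 nM in an assay on CHO cells for displacement of a labelled ligand from transient receptor potential cation channel subfamily V member 1 (Homo sapiens), read by scintillation counting, with a stated time of 60 min; on this read-out lower numbers stand for stronger inhibition and higher numbers for weaker inhibition; compound 1 `CN(C)C1(Cc2ccccc2)CCN(c2cc(C(F)(F)F)ccc2CNC(=O)Nc2ccc(NS(C)(=O)=O)c(F)c2)CC1` with 1160 nM; compound 2 `CN(C)C1(Cc2ccccc2)CCN(c2cc(C(F)(F)F)ccc2CNC(=O)Nc2cccc3ccc(O)cc23)CC1` with 0.46 nM.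

Compound 3 stands second highest of the three numbers, nearest to compound 1 and furthest from compound 2; the step of a 10-fold lower number from compound 1 to compound 3 (1.02 log units; beyond the scatter) and the step of a 240-fold higher number from compound 2 to compound 3 (2.38 log units; beyond the scatter) place it between them. Compound 4 `CN(C)C1(Cc2ccccc2)CCN(c2cc(C(F)(F)F)ccc2CNC(=O)Nc2cccc3cnccc23)CC1` differs from compound 3 in one place: a group of 10 heavy atoms (9 carbon, 1 nitrogen; one six-membered aromatic ring of carbon only, one six-membered aromatic ring with 1 hetero atom) in place of a group of 11 heavy atoms (9 carbon, 1 nitrogen, 1 oxygen; one six-membered aromatic ring of carbon only, one six-membered aromatic ring with 1 hetero atom), on an amide-type nitrogen.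

Every measured step bears on the same amide-type nitrogen: a 2500-fold lower number from compound 1 to compound 2 (3.40 log units; beyond the scatter), a 10-fold lower number from compound 1 to compound 3 (1.02 log units; beyond the scatter) and a 240-fold higher number from compound 2 to compound 3 (2.38 log units; beyond the scatter) are all large, so a change at this position can move the number in this assay a long way in either direction. Compound 4 keeps the two fused six-membered rings of compounds 2 and 3 but, like compound 2 and unlike compound 3, has no hydrogen-bond donor in the entering group. A lower number than for compound 3 is therefore expected, with wide uncertainty: the estimated step is a 22-fold lower number from compound 3 to compound 4 (1.35 log units; beyond the scatter). For compound 4 the estimate in this assay is 5 nM, with a range of 0.5 nM to 60 nM.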

Compound 4, inhibition constant: 0.67 nM
For compound 4 the middle estimate is 7.5-fold (0.87 log units) above the measured one; measured number inside the range.
By their numbers in this assay, from the lowest: compounds 2 and 4 (each within the scatter of the next); then compound 3; then compound 1.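

Isoquinolin-5-yl shows that a low number in this assay needs no hydrogen-bond donor in the group on this amide-type nitrogen: there is a 1.5-fold higher number from compound 2 to compound 4 (0.16 log units; within the scatter), so the number stays level with that of the hydroxyl-bearing 7-hydroxynaphthalen-1-yl group. Two fused rings alone do not settle the matter, since a 170-fold lower number from compound 3 to compound 4 (2.22 log units; beyond the scatter) separates two groups that share the same ring count, and a 1700-fold lower number from compound 1 to compound 4 (3.24 log units; beyond the scatter) sets isoquinolin-5-yl far from 3-fluoro-4-(methanesulfonamido)phenyl. No measurement at hand explains why the group leaving compound 3 gives so much higher a number.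

From the compounds shown here alone, it remains open whether plain naphthalen-1-yl, with neither the hydroxyl nor the ring nitrogen, would stay this low. Also open, going by these compounds, is whether an amine or a carboxylic acid added to isoquinolin-5-yl would keep the number.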